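The source may hold more compounds than are shown below. What is called first, only, known or untested is meant among the compounds shown, and "the series" means these compounds.

Compound 1 `CC(C)[C@H](C)NC(=O)c1ccc(C#Cc2cccc(F)c2)cn1`: 66.7%
Compound 2 `CC(C)(C)CNC(=O)c1ccc(C#Cc2cccc(F)c2)cn1`: 63.9%
Compound 3 `CC(C)(O)CNC(=O)c1ccc(C#Cc2cccc(F)c2)cn1`: 61.5%

These three compounds share one core and differ only in the group carried on the amide-type nitrogen. In a functional assay on HEK293 cells for positive allosteric modulation of metabotropic glutamate receptor 5 (Rattus norvegicus), read by fluorescence and calcium flux (a lower number here means a smaller maximal response, a higher number a larger maximal response), compound 1 gives 66.7%, compound 2 gives 63.9% and compound 3 gives 61.5%. The steps of a number 2.8 percentage points lower from compound 1 to compound 2 (within the scatter), a number 5.2 percentage points lower from compound 1 to compound 3 (within the scatter) and a number 2.4 percentage points lower from compound 2 to compound 3 (within the scatter) all stay within the scatter, so compound 3 stands among its neighbours rather than apart from them; the three numbers cannot be told apart with confidence.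

Compound 4 `CC1(CCNC(=O)c2ccc(C#Cc3cccc(F)c3)cn2)COC1` has not yet been measured. (3-methyloxetan-3-yl)methyl in place of 1-hydroxy-1-methylethyl on a saturated chain carbon bound to an amide-type nitrogen The measured step closest to this change is a number 2.4 percentage points lower from compound 2 to compound 3 (within the scatter), which also exchanged a group on the same branch and moved the maximal response only within the scatter; a number 5.2 percentage points lower from compound 1 to compound 3 (within the scatter), a larger reshaping of the branch, told the same story. Among the compounds with values here, with no step so far having moved the number beyond the scatter, the step expected here is estimated as a number 0.5 percentage points higher from compound 3 to compound 4 (within the scatter). Compound 4 is therefore estimated at 62%, expected to fall between 51% and 73%.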

Compound 4, largest response reached (reported as efficacy), in percent of the reference or control that the assay uses: 65.7%
The estimate for compound 4 lay 3.7 percentage points below the measured number; the range from low to high includes it.
By their numbers in this assay, from the lowest: compounds 3, 2, 4 and 1 (each within the scatter of the next).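

Putting (3-methyloxetan-3-yl)methyl in place of 1-hydroxy-1-methylethyl on a saturated chain carbon bound to an amide-type nitrogen adds a four-membered ring and removes the hydrogen-bond donor, yet this assay shows only a number 4.2 percentage points higher from compound 3 to compound 4 (within the scatter). Compared with the two compounds that carry no hydroxy, the result is the same: a number 1.8 percentage points higher from compound 2 to compound 4 (within the scatter) and a number 1 percentage points lower from compound 1 to compound 4 (within the scatter), so an open chain, a hydroxy-bearing chain and a ring-bearing chain cannot be told apart here by maximal response. Nothing available explains this result.

From the compounds shown here alone, whether an amine or a carboxylic acid at the end of this chain would shift the maximal response beyond the scatter remains open. So does the effect of a longer chain or a larger ring, such as tetrahydropyran, at this position.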